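Methoxy in Place of Fluoro on the Phenyl of Compound 2

A few compounds are considered here, and "the series" means these few. Any claim that something is new, unique, unknown or untested is made for them only; others in the source may bear on it.

In a functional assay on HeLa cells (Homo sapiens) for antiproliferative activity, read by sulforhodamine B assay, with a stated time of 48 h (on this read-out higher numbers stand for weaker inhibition of growth and lower numbers for stronger inhibition of growth), compound 1 `O=C(NCc1cn(Cc2ccc(Cl)cc2)nn1)c1cn(-c2ccccc2)nc1-c1ccc(F)cc1` gives 210 nM and compound 3 `COc1ccc(Cn2cc(CNC(=O)c3cn(-c4ccccc4)nc3-c3ccc(F)cc3)nn2)cc1OC` gives 200 nM. Compound 2 `O=C(NCc1cn(Cc2ccc(C(F)(F)F)cc2)nn1)c1cn(-c2ccccc2)nc1-c1ccc(F)cc1` gives 250 nM, the highest of the three numbers shown, though both a 1.2-fold higher number from compound 1 to compound 2 (0.08 log units; within the scatter) and a 1.3-fold lower number from compound 2 to compound 3 (0.10 log units; within the scatter) lie within the scatter. Compound 4 `COc1ccc(-c2nn(-c3ccccc3)cc2C(=O)NCc2cn(Cc3ccc(C(F)(F)F)cc3)nn2)cc1` differs from compound 2 in one place: methoxy in place of fluoro on an aromatic carbon. Going by the values given here, no measured step touches this ring; the steps measured so far all exchange the phenyl on the saturated chain carbon bound to an aromatic nitrogen, and none of them left the scatter. Compound 4 is therefore expected to give 250 nM in this assay, with a range from 100 nM to 700 nM, so that no change at the digits printed from compound 2 to compound 4 (within the scatter) is expected to stay within the scatter.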

Compound 4, concentration for 50% growth inhibition: 6200 nM
Beside the measured number, compound 4's estimate is 25-fold (1.39 log units) below it, outside the stated range (above it).
By their numbers in this assay, from the lowest: compounds 3, 1 and 2 (each within the scatter of the next); then compound 4.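

In this assay, the change from 4-fluorophenyl to 4-methoxyphenyl gives a 25-fold higher number from compound 2 to compound 4 (1.39 log units; beyond the scatter), which means weaker inhibition of growth. This is the first step shown to go beyond the scatter, and it marks this aromatic carbon, para to a large group, as a place where the read-out responds, unlike the exchanges at the other phenyl. Nothing available explains the loss. On these data alone, it remains open whether a hydroxy group, an amine or chloro would be tolerated here. As far as these compounds go, it also remains open whether methoxy has the same effect alongside the 4-chlorophenyl of compound 1 or the 3,4-dimethoxyphenyl of compound 3.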